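This account rests on a few compounds, and the source may have more. Where it says the series, first, only, none or still open, it means among the compounds named here.

Measured compounds:
- Compound 1, `Fc1ccccc1Cn1nnc2c(NC3CCCCC3)nc(-c3ccccc3)nc21`: 1150000 nM
- Compound 2, `CCCCNc1nc(-c2ccccc2)nc2c1nnn2Cc1ccccc1C(F)(F)F`: 6500000 nM
- Compound 3, `Fc1ccccc1Cn1nnc2c(NC3CC3)nc(-c3ccccc3)nc21`: 15000000 nM

All three were tested in an assay on isolated protein for binding affinity to adenosine receptor A1 (Bos taurus); on this read-out higher numbers stand for weaker inhibition and lower numbers for stronger inhibition. Among them compound 3 gives the highest number, so it is the weakest binder of the three; compound 2 is nearest to it, and compound 1 is furthest away. For the measured compounds named here, the one step that can be isolated within this set is a 13-fold higher number from compound 1 to compound 3 (1.12 log units; beyond the scatter), so trading a six-carbon ring for a three-carbon ring on the amine made binding much weaker.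

Compound 4, `CCCCNc1nc(-c2ccccc2)nc2c1nnn2Cc1ccccc1F`, has not yet been measured in this assay. It differs from compound 3 by butyl in place of cyclopropyl on a nitrogen on an aromatic ring. The step from compound 1 to compound 3 bears on this change: it shows that a smaller group on that nitrogen weakened binding, so moving from cyclopropyl to the longer butyl chain is expected to reverse part of that loss. Compound 2, which also carries a butyl on this nitrogen, gives a lower number than compound 3. For compound 4 the expected step is a 3.0-fold lower number from compound 3 to compound 4 (0.48 log units; beyond the scatter), toward stronger binding. The estimate for compound 4 in this assay is therefore 5000000 nM, with a range from 1500000 nM to 15000000 nM.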

Compound 4, inhibition constant: 4300000 nM
Compound 4: the middle estimate sits 1.2-fold (0.07 log units) above what was measured; the range from low to high includes it.
By their numbers in this assay, from the lowest: compound 1; then compounds 4 and 2 (each within the scatter of the next); then compound 3.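

In this assay, butyl on a nitrogen on an aromatic ring gives a 3.5-fold lower number from compound 3 to compound 4 (0.54 log units; beyond the scatter), which recovers part of the loss seen with cyclopropyl, while a 3.7-fold higher number from compound 1 to compound 4 (0.57 log units; beyond the scatter) shows that butyl still falls short of cyclohexyl. Fluoro in place of trifluoromethyl on an aromatic carbon, with butyl kept on the nitrogen, gives a 1.5-fold lower number from compound 2 to compound 4 (0.18 log units; within the scatter), so these two groups cannot be told apart here. No supporting data are available to explain any of these steps.

Open still is whether a longer chain such as hexyl, or a ring such as cyclopentyl, would bring the number closer to that of cyclohexyl. The compounds shown also leave open how chlorine or a methoxy group would compare with fluoro and trifluoromethyl on that aromatic carbon.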